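A Pyridinylsulfanyl Nucleoside Assessed for Cytotoxicity

The compounds below may be only part of what the source reports. "The series", "measured", "known", "first", "only" and "open" are said of these compounds alone.

Compound 1 `OC[C@H]1O[C@@H](n2cnc3c(COc4ccccc4)ncnc32)[C@H](O)[C@@H]1O`: > 100000 nM
Compound 2 `OC[C@H]1O[C@@H](n2cnc3c(CS)ncnc32)C[C@@H]1O`: 41000 nM
Compound 3 `[N-]=[N+]=NCc1ncnc2c1ncn2[C@@H]1O[C@H](CO)[C@@H](O)[C@H]1O`: > 250000 nM

In a functional assay on Huh-7 cells (Homo sapiens) for cytotoxicity, read by MTT assay, with a stated time of 3 days (a higher number here means that more compound is tolerated, a lower number that less compound is tolerated), compound 1 gives > 100000 nM, a limit of the assay. Compound 2 gives a number, 41000 nM, in this assay. Compound 3 gives > 250000 nM, which is again a limit. Compound 3 therefore stands at the limit of > 250000 nM in this assay, at which 1 of the 3 values shown sits, the higher of the two limits among the three values; the other is the limit of > 100000 nM in this assay, at which 1 of the 3 values shown sits. Going by the values given here, the single one-place step that reaches compound 3, a step that the two limits leave unreadable from compound 1 to compound 3, lies between two limits and gives no size. Compound 4 `OC[C@H]1O[C@@H](n2cnc3c(CSc4ccccn4)ncnc32)[C@H](O)[C@@H]1O` differs from compound 3 by (pyridin-2-yl)sulfanyl in place of azido on a saturated chain carbon bound to an aromatic carbon. Among the compounds with values here, no measured step bears on this change, so no direction beyond the scatter is claimed. Compound 4 is expected to give about 80000 nM in this assay, between 20000 nM and 250000 nM. The expected step of an at least 3.1-fold lower number from compound 3 to compound 4 (0.49 log units; beyond the scatter) is read against a limit.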

Compound 4, half-maximal cytotoxic concentration: > 100000 nM
Compound 4 was reported as a limit; the forecaster's own chance of this, stated with the estimate: 45%; middle value at least 1.2-fold (0.09 log units) from the limit.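

Going by these compounds alone, compound 4, like compound 1 and compound 3, stands only as a limit, so no step to compound 4 can be read. As far as these compounds go, whether phenoxy, azido and (pyridin-2-yl)sulfanyl differ in how much compound is tolerated stays open.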